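Second methyl-to-hydrogen exchange on compound 2

A few compounds are considered here, and "the series" means these few. Any claim that something is new, unique, unknown or untested is made for them only; others in the source may bear on it.

Compound 2 `COc1ccc2[nH]c(-c3ccccc3F)cc(=O)c2c1O` is the reference point of the series. In a functional assay on HCT-116 cells (Homo sapiens) for cytotoxicity, read by MTT assay, with a stated time of 48 h (on this read-out higher numbers stand for weaker inhibition and lower numbers for stronger inhibition), compound 2 gives 50 nM, the lowest of the two numbers shown; its nearest neighbour is compound 3 `COc1ccc2[nH]c(-c3cccc(F)c3)cc(=O)c2c1O`, which in this assay gives 70 nM, the pair differing by a 1.4-fold higher number from compound 2 to compound 3 (0.15 log units; within the scatter) through 3-fluorophenyl in place of 2-fluorophenyl on an aromatic carbon. Compound 1 `COc1ccc2[nH]c(-c3ccccc3F)cc(=O)c2c1OC` stands apart: in this assay compound 1 gives > 20000 nM, a limit of the assay and not a number. Going by the values given here, the step of an at least 400-fold lower number from compound 1 to compound 2 (2.60 log units; beyond the scatter) is the one measured precedent for the change now considered, hydrogen in place of methyl on an oxygen on an aromatic ring, read one bond further out as methoxy to hydroxy; the limit of > 20000 nM in this assay, at which 1 of the 3 values shown sits, marks its starting point as a limit, so its true size is open.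

Compound 4 `O=c1cc(-c2ccccc2F)[nH]c2ccc(O)c(O)c12` repeats that change on the remaining oxygen: hydrogen in place of methyl on an oxygen on an aromatic ring. The precedent an at least 400-fold lower number from compound 1 to compound 2 (2.60 log units; beyond the scatter) is large and downward, yet it starts from a limit and concerns a different oxygen, so an equal gain for compound 4 is not assumed. For compound 4 a step of a 1.3-fold lower number from compound 2 to compound 4 (0.10 log units; within the scatter) is expected in this assay, at most modestly downward and close to the scatter. Compound 4 is accordingly estimated at 40 nM, between 10 nM and 200 nM.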

Compound 4, half-maximal inhibitory concentration: 600 nM
For compound 4 the middle estimate is 15-fold (1.18 log units) below the measured one; the measured number lies above the stated range.
By their numbers in this assay, from the lowest: compounds 2 and 3 (each within the scatter of the next); then compound 4. At a limit, above all of these: compound 1.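

In this assay, the exchange of methyl for hydrogen on an oxygen on an aromatic ring has no single direction in this series: an at least 400-fold lower number from compound 1 to compound 2 (2.60 log units; beyond the scatter) stands against a 12-fold higher number from compound 2 to compound 4 (1.08 log units; beyond the scatter), so the outcome depends on which of the two oxygens carries the change. The methoxy that remains in compound 2 therefore cannot be treated as a freely exchangeable end group, and compound 2, with one methoxy and one hydroxy, has a lower number than compound 1, with both oxygens as methoxy, and compound 4, with both as hydroxy. The two steps can be compared in direction only, not in size: the limit of > 20000 nM in this assay, at which 1 of the 4 values shown sits.

The compounds shown leave open whether the loss at this oxygen is specific to hydrogen or whether another group there, such as an ethoxy, a longer chain or an amine-bearing chain, would restore or further lower the number. They also leave open whether the same methoxy to hydroxy step holds when 3-fluorophenyl, as in compound 3, takes the place of 2-fluorophenyl.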